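The source may report more compounds than this note shows. Statements on the series, on what has been measured and on what is new or still open speak of the compounds shown alone.

- compound 1 `COc1cccc(-c2nc(N)c(Oc3ccccc3OC)c(Cl)n2)c1`: 23600 nM
- compound 2 `COc1ccccc1Oc1c(N)nc(-c2cccc(F)c2)nc1Cl`: 21700 nM
- compound 3 `COc1ccccc1Oc1c(N)nc(-c2cccc(Cl)c2)nc1Cl`: 17900 nM

In a functional assay on B16 cells (Mus musculus) for cytotoxicity, read by CCK-8 assay, with a stated time of 24 h (a higher number here means a weaker inhibitor, a lower number a stronger inhibitor), compound 1 gives 23600 nM and stands level with the other two compounds, since its steps to both lie within the scatter. Compound 4 `COc1ccccc1Oc1c(N)nc(-c2cccc(Br)c2)nc1Cl` is not yet measured. It differs from compound 1 by bromo in place of methoxy on an aromatic carbon, which turns the 3-methoxyphenyl into 3-bromophenyl.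

Two measured steps change the same group: fluoro in place of methoxy (a 1.1-fold lower number from compound 1 to compound 2 (0.04 log units; within the scatter)) and chloro in place of methoxy (a 1.3-fold lower number from compound 1 to compound 3 (0.12 log units; within the scatter)). Chloro in place of fluoro (a 1.2-fold lower number from compound 2 to compound 3 (0.08 log units; within the scatter)) bears on it as well. All three stay within the scatter, so no step beyond the scatter is expected in this assay and no firm direction can be read from them.

The expected change is small (a 1.2-fold lower number from compound 1 to compound 4 (0.09 log units; within the scatter)) and would not exceed the scatter. Compound 4 is estimated at 19000 nM with an expected range from 11000 nM to 31000 nM for its measurement.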

Compound 4, half-maximal inhibitory concentration: 24600 nM
The estimate for compound 4 lay 1.3-fold (0.11 log units) below the measured number; the range from low to high includes it.
By their numbers in this assay, from the lowest: compounds 3, 2, 1 and 4 (each within the scatter of the next).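

In this assay, the 3-bromophenyl of compound 4 adds a third halogen at this place, and replacing methoxy with bromo stays within the scatter (a 1.0-fold higher number from compound 1 to compound 4 (0.02 log units; within the scatter)). The steps from the two other halogens also stay within the scatter (a 1.1-fold higher number from compound 2 to compound 4 (0.05 log units; within the scatter); a 1.4-fold higher number from compound 3 to compound 4 (0.14 log units; within the scatter)), so methoxy, fluoro, chloro and bromo cannot be told apart at this position in this assay, and the four compounds show no trend across the halogens. No measurement at hand offers an explanation for this result.

Going by these compounds, only methoxy and halogens appear at this position, so it remains open whether an amine, a carboxylic acid or a longer chain would give a step beyond the scatter. On these data alone, the rest of the shared core is the same in all four compounds, so the effect of changes elsewhere also remains open.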